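From pyridin-2-yl to ethylcarbamoyl: an expected rise in clearance

The source may hold more compounds than are shown below. What is called first, only, known or untested is meant among the compounds shown, and "the series" means these compounds.

In an ADME assay on microsomes from liver (Rattus norvegicus) for pharmacokinetics, using NADPH, with a stated time of 30 min, tested at 1 uM (on this read-out lower numbers stand for slow clearance and higher numbers for fast clearance), compound 1 `C[C@H](Nc1ncnc(N)c1C#N)c1nc2ccc(F)cc2c(-c2ccccn2)c1-c1ccccn1` gives 16 mL.min-1.g-1, the lowest of the three numbers. Compound 3 `C[C@H](Nc1ncnc(N)c1C#N)c1nc2ccc(F)cc2c(C(=O)N2CC(O)C2)c1-c1ccccc1` gives 49 mL.min-1.g-1, and compound 2 `C[C@H](Nc1ncnc(N)c1C#N)c1nc2ccc(F)cc2c(C(=O)N(C)C)c1-c1ccccc1` gives 426 mL.min-1.g-1. Compound 4 `CCNC(=O)c1c(-c2ccccn2)c([C@H](C)Nc2ncnc(N)c2C#N)nc2ccc(F)cc12` differs from compound 1 by ethylcarbamoyl in place of pyridin-2-yl on an aromatic carbon. Going by the values given here, no measured step makes this exchange directly. Among the compounds with values here, the only measured step, an 8.7-fold lower number from compound 2 to compound 3 (0.94 log units; beyond the scatter), changes the group on a carbonyl carbon and shows how far such a change can move this assay. Both compounds with that carbonyl stand higher than compound 1, the closer being compound 3 at 49 mL.min-1.g-1, so a rise beyond the scatter is expected. The expected change is a 3.8-fold higher number from compound 1 to compound 4 (0.57 log units; beyond the scatter). Compound 4 is estimated at 60 mL.min-1.g-1, with an expected range from 20 mL.min-1.g-1 to 180 mL.min-1.g-1.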

Compound 4, intrinsic clearance in microsomes: < 14 mL.min-1.g-1
Compound 4 was reported as a limit; the forecaster's own chance of this, stated with the estimate: 3%; middle value at least 4.2-fold (0.63 log units) away from the limit.
By their numbers in this assay, from the lowest: compound 1; then compound 3; then compound 2. At a limit, below all of these: compound 4.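

In this assay compound 4 is reported only as a limit: the limit of < 14 mL.min-1.g-1 in this assay, at which 1 of the 4 values shown sits. Ethylcarbamoyl in place of pyridin-2-yl on this aromatic carbon gives an at least 1.1-fold lower number from compound 1 to compound 4 (0.05 log units; that floor lies within the scatter), so the exchange brings no rise in clearance, although the floor of that step does not establish a fall. The amide thus stands at this position with clearance as low as the pyridin-2-yl of compound 1 allows this assay to show.

Going by these compounds, how far compound 4 lies under its limit stays open. So does whether a longer chain, a cyclopropyl or a methyl on the amide nitrogen would hold the number down in the same way.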